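A Second 4-Nitrobenzyl Group on Compound 3

The source may report more compounds than this note shows. Statements on the series, on what has been measured and on what is new or still open speak of the compounds shown alone.

Three related compounds have been tested so far. In a functional assay on HeLa cells (Homo sapiens), read by microscopy (a lower number here means a stronger inhibitor, a higher number a weaker inhibitor), compound 1 `COC1=C(OC)/C(=C/Cn2cnc3c(Cl)ncnc32)OC1=O` gives 23400 nM while compound 2 `COC1=C(OCc2ccc([N+](=O)[O-])cc2)/C(=C\Cn2cnc3c(Cl)ncnc32)OC1=O` gives 19300 nM and compound 3 `COC1=C(OCc2ccc([N+](=O)[O-])cc2)C(=O)O/C1=C/Cn1cnc2c(Cl)ncnc21` gives 20200 nM on the same scale. Compound 3 therefore stands within the usual scatter of both other compounds, and the three numbers cannot be ranked, since repeat measurements of this kind vary by that much. No two of these compounds differ in one place only, so no single structural step has been measured yet.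

Compound 4 `O=C1O/C(=C/Cn2cnc3c(Cl)ncnc32)C(OCc2ccc([N+](=O)[O-])cc2)=C1OCc1ccc([N+](=O)[O-])cc1` is the next to be tested. It departs from compound 3 by one change (4-nitrophenyl in place of hydrogen on a saturated chain carbon bound to an oxygen on an unsaturated carbon): 4-nitrophenyl in place of hydrogen on a saturated chain carbon bound to an oxygen on an unsaturated carbon, which turns methoxy into (4-nitrobenzyl)oxy.

Compound 1 at 23400 nM and compound 3 at 20200 nM lie within the scatter of each other, so in this assay no step beyond the scatter is expected. The estimated step is a 1.1-fold lower number from compound 3 to compound 4 (0.05 log units; within the scatter) and stays within that scatter. Compound 4 is expected at 18000 nM with an estimated range of 8000 nM to 40000 nM for its measurement.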

Compound 4, half-maximal inhibitory concentration: 17000 nM
Estimate against measurement, compound 4: 1.1-fold (0.02 log units) above; the measured number falls inside the stated range.
By their numbers in this assay, from the lowest: compounds 4, 2, 3 and 1 (each within the scatter of the next).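

In this assay, within the data shown here, the swap of methoxy for (4-nitrobenzyl)oxy can now be read on its own for the first time, as a 1.2-fold lower number from compound 3 to compound 4 (0.07 log units; within the scatter), and this places the 4-nitrophenyl group on a saturated chain carbon bound to an oxygen on an unsaturated carbon. The same kind of change at the other such oxygen reads as a 1.1-fold lower number from compound 2 to compound 4 (0.06 log units; within the scatter), so in these two direct comparisons neither methoxy-to-(4-nitrobenzyl)oxy swap moves the number beyond the scatter, and compound 4, with its two 4-nitrobenzyl groups, cannot be told apart from compound 2 or compound 3 in this assay. No independent measurement is available here to explain why these steps are so small.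

The compounds shown leave open whether a different group at these oxygens, such as a longer chain like n-butyl or a benzyl carrying an amine or a carboxylic acid in place of the nitro group, would give a step beyond the scatter. They also leave open whether changing the shared core, rather than these two oxygen substituents, would shift the number more.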